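The source may report more compounds than this note shows. Statements on the series, on what has been measured and on what is new or still open speak of the compounds shown alone.

Working notes on the series in an assay on isolated protein for inhibition of Retinaldehyde dehydrogenase 3 (Homo sapiens); a higher number here means a weaker inhibitor, a lower number a stronger inhibitor.

Three members have been measured. Compound 1 `C#Cc1ccc(-n2c(SC(C)c3ccccc3)nc3c(cnn3C)c2=O)cc1` gives 520 nM. Compound 2 `CC(Sc1nc2c(cnn2C)c(=O)n1-c1ccccc1)c1ccccc1` gives 73 nM. Compound 3 `CC(Sc1nc2c(cnn2C)c(=O)n1-c1ccc(CO)cc1)c1ccccc1` gives 1000 nM. Compound 3 therefore carries the highest of the three numbers: its gap to compound 1 is within the scatter, while its gap to compound 2 is beyond it.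

The measured steps are of two sizes. Putting hydrogen in place of ethynyl gave a 7.1-fold lower number from compound 1 to compound 2 (0.85 log units; beyond the scatter), a modest step. Putting hydroxymethyl in place of ethynyl gave a 1.9-fold higher number from compound 1 to compound 3 (0.28 log units; within the scatter), which is within the scatter. Putting hydroxymethyl in place of hydrogen gave a 14-fold higher number from compound 2 to compound 3 (1.14 log units; beyond the scatter), a large step. Taken together, the unsubstituted phenyl of compound 2 does best here, and the two substituted phenyls of compound 1 and compound 3 sit close to each other.

Compound 4 `CC(Sc1nc2c(cnn2C)c(=O)n1-c1ccc(CCO)cc1)c1ccccc1` is the next member. Against compound 3 the change is hydroxymethyl in place of hydroxy on a saturated chain carbon bound to an aromatic carbon, so the 4-(hydroxymethyl)phenyl becomes a 4-(2-hydroxyethyl)phenyl. Going by the values given here, no measured step lengthens the chain at this position; the only guidance is that compound 1 and compound 3 differ by a 1.9-fold higher number from compound 1 to compound 3 (0.28 log units; within the scatter) despite carrying different groups there. A step of about that size, in either direction, is the most that is expected, and none beyond the scatter is the central guess.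

Compound 4 is estimated at 1100 nM, with a range from 400 nM to 3000 nM. This estimate amounts to a 1.1-fold higher number from compound 3 to compound 4 (0.04 log units; within the scatter).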

Compound 4, half-maximal inhibitory concentration: 3000 nM
Estimate against measurement, compound 4: 2.7-fold (0.44 log units) below; measured number inside the range.
By their numbers in this assay, from the lowest: compound 2; then compounds 1 and 3 (each within the scatter of the next); then compound 4.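

In this assay, the change from 4-(hydroxymethyl)phenyl to 4-(2-hydroxyethyl)phenyl is not neutral: a 3.0-fold higher number from compound 3 to compound 4 (0.48 log units; beyond the scatter), so the length of the chain at this position registers in the numbers. Against the unsubstituted phenyl, a 41-fold higher number from compound 2 to compound 4 (1.61 log units; beyond the scatter), the largest step in the series so far, and all three groups on the phenyl now give higher numbers than hydrogen, with no compound among the four going against this. Hydroxymethyl could not be told apart from ethynyl, but 2-hydroxyethyl can: a 5.8-fold higher number from compound 1 to compound 4 (0.76 log units; beyond the scatter), which leaves compound 4 as the weakest inhibitor of the four, with its steps to all the others beyond the scatter.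

Open, going by these compounds, is whether a plain ethyl, a methoxy or a carboxylic acid on the phenyl would sit nearer compound 2 at 73 nM or nearer compound 4, and so whether the chain or its hydroxy goes with the higher numbers. Nothing available on this series offers an explanation for these steps.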